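A few compounds are considered here, and "the series" means these few. Any claim that something is new, unique, unknown or untested is made for them only; others in the source may bear on it.

Compound 1, `O=C(CCc1ccc(C(F)(F)F)cc1)Nc1ccc2nc(N3CCCCC3)ccc2c1`, is the reference point of this small set. In a functional assay on HEK293 cells for activation of melanin-concentrating hormone receptor 1 (Rattus norvegicus), read by inositol phosphate accumulation (a higher number here means that more compound is needed for the effect, a lower number that less compound is needed), compound 1 gives 110 nM, the lowest of the three numbers measured. Its nearest neighbour is compound 3, `Nc1ccc2cc(NC(=O)CCc3ccc(C(F)(F)F)cc3)ccc2n1`, which gives 720 nM in this assay; compound 2, `O=C(CCc1ccc(C(F)(F)F)cc1)Nc1ccc2nc(N3CCC(c4ccccc4)C3)ccc2c1`, gives 1770 nM and lies furthest away.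

The unmeasured compound 4, `O=C(CCc1ccc(C(F)(F)F)cc1)Nc1ccc2nc(N3CC4CCC3CC4)ccc2c1`, differs from compound 1 at one point: a group of 8 heavy atoms (7 carbon, 1 nitrogen; 2 six-membered non-aromatic rings with 1 hetero atom each) in place of a group of 6 heavy atoms (5 carbon, 1 nitrogen; one six-membered non-aromatic ring with 1 hetero atom), on an aromatic carbon

Among the compounds with values here, two measured steps touch the same aromatic carbon. Replacing piperidin-1-yl by 3-phenylpyrrolidin-1-yl gave a 16-fold higher number from compound 1 to compound 2 (1.21 log units; beyond the scatter), while replacing it by amino gave a 6.5-fold higher number from compound 1 to compound 3 (0.82 log units; beyond the scatter). Both a much larger substituent and a much smaller one therefore raised the number beyond the scatter, with the larger one doing more harm. The group entering in compound 4 is larger than piperidin-1-yl but by far less than the group in compound 2, so a modest rise in this assay is expected for compound 4, smaller than either measured step and possibly within the scatter, which is expected to correspond to a 2.3-fold higher number from compound 1 to compound 4 (0.36 log units; beyond the scatter).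

Compound 4 is therefore estimated to give 250 nM in this assay, with a range from 80 nM to 800 nM.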

Compound 4, half-maximal effective concentration: 190 nM
Estimate against measurement, compound 4: 1.3-fold (0.12 log units) above; the range from low to high includes it.
By their numbers in this assay, from the lowest: compounds 1 and 4 (each within the scatter of the next); then compound 3; then compound 2.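

At this position, a group larger than piperidin-1-yl, with two six-membered non-aromatic rings, does not have to raise the number in this assay: the step (a 1.7-fold higher number from compound 1 to compound 4 (0.24 log units; within the scatter)) stays within the scatter. The rise seen with 3-phenylpyrrolidin-1-yl therefore does not apply to every enlargement of the group on this aromatic carbon. The new group also keeps a clear distance from both the amino group (a 3.8-fold lower number from compound 3 to compound 4 (0.58 log units; beyond the scatter)) and 3-phenylpyrrolidin-1-yl (a 9.3-fold lower number from compound 2 to compound 4 (0.97 log units; beyond the scatter)), so the two cyclic amines with six-membered rings form the low end of this small series, although two examples establish no general rule.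

Going by these compounds, it remains open whether morpholin-4-yl or an open-chain diethylamino group on the same carbon would also stay close to piperidin-1-yl, and whether a phenyl group carried on a six-membered ring would bring the same rise as 3-phenylpyrrolidin-1-yl. No measurement at hand offers an explanation for any of these differences.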